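The source may hold more compounds than are shown below. What is called first, only, known or untested is meant among the compounds shown, and "the series" means these compounds.

Measured so far:
compound 1 `CC(C)(C)OC(=O)N1CCC(O[C@H]2CC[C@H](Oc3ccc(S(C)(=O)=O)cc3)CC2)CC1` – 16.1 nM
compound 2 `CC(C)(C)OC(=O)N1CCC(O[C@H]2CC[C@H](Oc3ccc(S(C)(=O)=O)cn3)CC2)CC1` – 47 nM
compound 3 `CC(C)OC(=O)N1CCC(O[C@H]2CC[C@H](Oc3ccc(S(C)(=O)=O)nc3)CC2)CC1` – 13 nM

In a functional assay on isolated protein for agonist activity at Glucose-dependent insulinotropic receptor (Homo sapiens), read by HTRF and cAMP accumulation (a higher number here means that more compound is needed for the effect, a lower number that less compound is needed), compound 3 stands at the lowest of the three numbers; the gap to compound 1 is within the scatter, the gap to compound 2 beyond it. Compound 4 `Cc1nc(S(C)(=O)=O)ccc1O[C@H]1CC[C@H](OC2CCN(C(=O)OC(C)C)CC2)CC1` differs from compound 3 by methyl in place of hydrogen on an aromatic carbon. Going by the values given here, no measured step covers a change of this kind. Among the compounds with values here, the only single-point step available, a 2.9-fold higher number from compound 1 to compound 2 (0.47 log units; beyond the scatter), concerns an exchange of the whole aryl group and does not bear on a methyl added to it. Compounds 1 and 3 differ in two places, and their values lie within the scatter of each other. The step is therefore expected to be small, no change at the digits printed from compound 3 to compound 4 (within the scatter), with no direction beyond the scatter. Compound 4 is estimated at 13 nM, range 5 nM to 40 nM.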

Compound 4, half-maximal effective concentration: 11 nM
Estimate against measurement, compound 4: 1.2-fold (0.07 log units) above; measured number inside the range.
By their numbers in this assay, from the lowest: compounds 4, 3 and 1 (each within the scatter of the next); then compound 2.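

In this assay, methyl in place of hydrogen on the aromatic carbon next to the ring nitrogen gives a 1.2-fold lower number from compound 3 to compound 4 (0.07 log units; within the scatter), within the scatter. Going by these compounds alone, this position, ortho to a large group, therefore accepts one added carbon without a measurable change, which the earlier compounds, all unsubstituted there, could not show. Nothing available explains this tolerance. Still open, going by these compounds, is whether an ethyl, a methoxy or an amine on this carbon would be tolerated as well. Also open, on these data alone, is how methyl behaves on the other aromatic carbons of this ring.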